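A few compounds are considered here, and "the series" means these few. Any claim that something is new, unique, unknown or untested is made for them only; others in the source may bear on it.

Working notes on the series. In a functional assay on MCF7 cells (Homo sapiens) for inhibition, read by sulforhodamine B assay (a higher number here means a weaker inhibitor, a lower number a stronger inhibitor), compound 2 `O=C1C=C(Nc2ccccc2)C(=O)c2c1nc1n2[C@H]2OC[C@@H](O)[C@H]2OC1` gives > 4000 nM, which is a limit of the assay and not a number. Compound 1 `COc1cccc(NC2=CC(=O)c3nc4n(c3C2=O)[C@H]2OC[C@@H](O)[C@H]2OC4)c1` gives > 4000 nM, likewise a limit. Compound 3 `CCCc1ccc(NC2=CC(=O)c3nc4n(c3C2=O)[C@H]2OC[C@@H](O)[C@H]2OC4)cc1` gives 4660 nM. Compound 2 thus stands at the limit of this assay, where (the limit of > 4000 nM in this assay, at which 2 of the 3 values shown sit), and its value can be ordered against neither compound 1 nor compound 3. The three measured steps, a step that the two limits leave unreadable from compound 1 to compound 2, a step that the limit leaves unreadable from compound 1 to compound 3 and a step that the limit leaves unreadable from compound 2 to compound 3, all alter the anilino group of the shared core, and none of them can be read for size.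

The step to compound 4 `O=C1C=C(N2CCCCC2)C(=O)c2c1nc1n2[C@H]2OC[C@@H](O)[C@H]2OC1` is piperidin-1-yl in place of anilino on a double-bonded ring carbon. Within the data shown here, none of the measured steps replaces the anilino group itself, so no measured step bears on this change directly; what bears on it only loosely is that every change made so far around the anilino group has left the value of this assay at or close to the limit. The step from compound 2 to compound 4 is therefore expected to be a step that the limit leaves unreadable from compound 2 to compound 4, which is to say nothing readable beyond the scatter. For compound 4 the value in this assay is estimated at 6000 nM, within a range from 2500 nM to 15000 nM.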

Compound 4, half-maximal inhibitory concentration: > 8000 nM
Compound 4 was reported as a limit; the forecaster's own chance of this, stated with the estimate: 55%; middle value at least 1.3-fold (0.12 log units) from the limit.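

In this assay compound 4 gives > 8000 nM, which is a limit of the assay and not a number. Its comparisons with compound 1 and compound 2 set limit against limit, so neither new step can be read for size. The compounds shown leave open whether piperidin-1-yl in place of anilino changes the value at all, and in which direction.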